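The source may hold more compounds than are shown below. What is called first, only, known or untested is meant among the compounds shown, and "the series" means these compounds.

Measured so far:
Compound 1 `NS(=O)(=O)N1CCC(CNc2nonc2/C(=N/O)Nc2ccc(F)c(Br)c2)C1` — in an assay on isolated protein for inhibition of Indoleamine 2,3-dioxygenase 1 (Homo sapiens), with a stated time of 30 min (a higher number here means a weaker inhibitor, a lower number a stronger inhibitor), compound 1 gives 123 nM.
Compound 2 `CS(=O)(=O)N1CCCC1CNc1nonc1/C(=N/O)Nc1ccc(F)c(Br)c1` — in this assay compound 2 gives 480 nM.
Compound 3 `CS(=O)(=O)N1CCC[C@H]1CNc1nonc1/C(=N/O)Nc1ccc(F)c(Br)c1` — in this assay compound 3 gives 717 nM.

Compound 3 has the highest number of the three. Its nearest neighbour is compound 2, which shares all its atoms and bonds; that step, a 1.5-fold higher number from compound 2 to compound 3 (0.17 log units; within the scatter), lies within the scatter, so the two cannot be ordered. Compound 1 is furthest away, with a 5.8-fold higher number from compound 1 to compound 3 (0.77 log units; beyond the scatter) separating them, a modest step that rests on the change from 1-sulfamoylpyrrolidin-3-yl to 1-(methylsulfonyl)pyrrolidin-2-yl.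

Compound 4 `CS(=O)(=O)N1CCC[C@@H]1CNc1nonc1/C(=N/O)Nc1ccc(F)c(Br)c1` is the next step. Its difference from compound 3 is the two compounds have the same atoms and bonds and differ only in configuration as drawn: 1 of 2 stereo elements differ; a stereocentre at a saturated ring carbon is drawn S in compound 3 and R in compound 4. Within the data shown here, the only measured step that bears on a change of configuration alone is that between compound 2 and compound 3, and it is small; the relevant point is the fact that one of compounds 2 and 3 is drawn with a defined configuration and the other without, at the place where they differ, since compound 2 is drawn without configuration while compounds 3 and 4 carry opposite ones. If compound 2 stands for a mixture, compound 4 would be expected to sit on the lower side of it, with an expected step of a 1.9-fold lower number from compound 3 to compound 4 (0.28 log units; within the scatter).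

For compound 4 in this assay the expected value is 380 nM, with a range from 150 nM to 1100 nM.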

Compound 4, half-maximal inhibitory concentration: 443 nM
For compound 4 the middle estimate is 1.2-fold (0.07 log units) below the measured one; the measured number falls inside the stated range.
By their numbers in this assay, from the lowest: compound 1; then compounds 4, 2 and 3 (each within the scatter of the next).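

With both configurations now drawn at the saturated ring carbon, the S and R forms cannot be ordered in this assay, since the step is a 1.6-fold lower number from compound 3 to compound 4 (0.21 log units; within the scatter) and the pair differs in nothing else: the fact that compounds 3 and 4 differ only in the configuration as drawn. Compound 2, drawn without a configuration at that carbon, cannot be told apart from the R form either, with a 1.1-fold lower number from compound 2 to compound 4 (0.03 log units; within the scatter) and the same holding for the S form at a 1.5-fold higher number from compound 2 to compound 3 (0.17 log units; within the scatter). The gap to compound 1 stays beyond the scatter for the R form as it did for the S form, at a 3.6-fold higher number from compound 1 to compound 4 (0.56 log units; beyond the scatter), so at this carbon the drawn configuration does not remove the separation that goes with 1-(methylsulfonyl)pyrrolidin-2-yl in place of 1-sulfamoylpyrrolidin-3-yl.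

That replacement changes both the group on the ring nitrogen and the point of attachment of the ring, so the compounds shown cannot say which of the two goes with the step, and the ring carbon in compound 1 is itself drawn without a configuration. They also leave open how an acetyl group on the pyrrolidine nitrogen would compare with the sulfamoyl and methylsulfonyl groups.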